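Swapping the pendant phenyl substituent at the shared core

A few compounds are considered here, and "the series" means these few. Any claim that something is new, unique, unknown or untested is made for them only; others in the source may bear on it.

Measured compounds:
Compound 1 `CCCS(=O)(=O)Nc1ccc(F)c(C(=O)c2n[nH]c3ncc(-c4ccccc4N)cc23)c1F` — 23%
Compound 2 `CCCS(=O)(=O)Nc1ccc(F)c(C(=O)c2n[nH]c3ncc(-c4ccc(C)c(C)c4)cc23)c1F` — 20%

Both compounds were tested in an assay for binding affinity to dual specificity mitogen-activated protein kinase kinase 4 (Homo sapiens), read by KINOMEscan, tested at 100 nM; a lower number here means a stronger effect, a higher number a weaker effect of the compound at the concentration tested. Compound 1 gives 23%, and compound 2 gives 20%, so compound 2 stands alongside compound 1: the change a number 3 percentage points lower from compound 1 to compound 2 (within the scatter) is within the scatter, and no order between the two can be read from these numbers.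

Compound 3 `CCCS(=O)(=O)Nc1ccc(F)c(C(=O)c2n[nH]c3ncc(-c4ccc(C(C)(C)C)cc4)cc23)c1F` differs from compound 2 in one place: 4-(tert-butyl)phenyl in place of 3,4-dimethylphenyl on an aromatic carbon. Going by the values given here, the only measured step that bears on it, a number 3 percentage points lower from compound 1 to compound 2 (within the scatter), was small, and it concerns a different exchange on the same aromatic carbon. The data therefore give no footing for a step beyond the scatter in this assay from compound 2 to compound 3 in either direction. Compound 3 is thus expected to give 25%, estimated within the range 8% to 55%, which means an expected step of a number 5 percentage points higher from compound 2 to compound 3 (within the scatter).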

Compound 3, a percentage reported as activity, at one concentration (the size of the read-out at that concentration, not a potency): 46%
Beside the measured number, compound 3's estimate is 21 percentage points below it, within the range that was stated.
By their numbers in this assay, from the lowest: compounds 2 and 1 (each within the scatter of the next); then compound 3.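

At this aromatic carbon the choice of pendant phenyl group does matter in this assay after all: 4-(tert-butyl)phenyl in place of 3,4-dimethylphenyl gives a number 26 percentage points higher from compound 2 to compound 3 (beyond the scatter) and 4-(tert-butyl)phenyl in place of 2-aminophenyl gives a number 23 percentage points higher from compound 1 to compound 3 (beyond the scatter) at the same position. Going by these compounds alone, the earlier exchange had stayed within the scatter, so this is the first change here to weaken the effect at the concentration tested by more than that scatter. No supporting measurement is available to explain this step.

The compounds shown leave open whether the weaker effect belongs to the tert-butyl group itself or would also appear with a smaller group on the phenyl ring. A 4-isopropylphenyl or 4-methylphenyl group at this carbon would bear directly on that question.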